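Bombesin receptor subtype-3 agonists: alkyl side-chain variation

A few compounds are considered here, and "the series" means these few. Any claim that something is new, unique, unknown or untested is made for them only; others in the source may bear on it.

Measured so far:
compound 1, `O=C(O)c1ccccc1-c1ccc(CCc2ncc(CC3CCC3)[nH]2)cc1`: 588 nM
compound 2, `O=C(O)c1ccccc1-c1ccc(CCc2ncc(CCc3ccccc3)[nH]2)cc1`: 1320 nM

Two compounds of the shared core have been run in an in vitro functional assay on cells for agonist activity at Bombesin receptor subtype-3 (Homo sapiens), read by luminescence and calcium flux; a higher number here means that more compound is needed for the effect, a lower number that less compound is needed. Going by the values given here, compound 1 gives 588 nM and compound 2 gives 1320 nM; the single step between them, a 2.2-fold higher number from compound 1 to compound 2 (0.35 log units; beyond the scatter), places compound 2 at the highest number of the two, with compound 1 as its nearest neighbour.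

The next compound, compound 3, `CCC(C)(CC)Cc1cnc(CCc2ccc(-c3ccccc3C(=O)O)cc2)[nH]1`, is not yet measured. It differs from compound 2 in one place: 1-ethyl-1-methylpropyl in place of benzyl on a saturated chain carbon bound to an aromatic carbon.

Among the compounds with values here, only one measured step bears on this change, a 2.2-fold higher number from compound 1 to compound 2 (0.35 log units; beyond the scatter), where the benzyl group went with a modestly higher number than the cyclobutyl group. Compound 3 returns to a saturated substituent, here without a ring, so the expected direction is back toward the number of compound 1. On that basis the step expected is a 2.0-fold lower number from compound 2 to compound 3 (0.31 log units; beyond the scatter) in this assay. Compound 3 is therefore estimated at 650 nM, within a range of 250 nM to 1700 nM.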

Compound 3, half-maximal effective concentration: 76 nM
For compound 3 the middle estimate is 8.6-fold (0.93 log units) above the measured one, and the stated range ends above it.
By their numbers in this assay, from the lowest: compound 3; then compound 1; then compound 2.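

On a saturated chain carbon bound to an aromatic carbon, a ring in the substituent is not required for a low number in this assay, as 1-ethyl-1-methylpropyl in place of benzyl gives a 17-fold lower number from compound 2 to compound 3 (1.24 log units; beyond the scatter) and the same group in place of cyclobutyl gives a 7.7-fold lower number from compound 1 to compound 3 (0.89 log units; beyond the scatter) in this series. Going by these compounds alone, the substituent at this position therefore shifts the number far more than the cyclobutyl and benzyl pair alone showed, and the lowest of the three numbers belongs to the only group without a ring. Nothing available explains the size of these steps.

Still open, from the compounds shown here alone, is whether the branching of 1-ethyl-1-methylpropyl matters, which an unbranched n-hexyl chain or a cyclohexyl ring at the same place would address. Also open, going by these compounds, is whether a hydroxyl or an amine on this chain would keep the number as low.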